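A few compounds are considered here, and "the series" means these few. Any claim that something is new, unique, unknown or untested is made for them only; others in the source may bear on it.

Three close relatives of one sulfonamide have been measured in a functional assay on MCF7 cells (Homo sapiens) for antiproliferative activity, read by sulforhodamine B assay, with a stated time of 48 h; on this read-out lower numbers stand for stronger inhibition and higher numbers for weaker inhibition. Compound 1 `COc1ccc(NS(=O)(=O)c2ccc(N3CCNC3=O)cc2)cc1` is recorded in this assay only as a limit, > 1000 nM. Compound 3 `CC(C)(C)c1ccc(NS(=O)(=O)c2ccc(N3CCNC3=O)cc2)cc1` likewise reaches only the limit of this assay, > 1000 nM. Among the measured compounds shown here, compound 2 `Cc1ccccc1NS(=O)(=O)c1ccc(N2CCNC2=O)cc1` in this assay gives 280 nM, which is the only actual number among the three. For the measured compounds named here, the step of an at least 3.5-fold lower number from compound 1 to compound 2 (0.55 log units; beyond the scatter) is the one readable change at the sulfonamide nitrogen, while the step that the two limits leave unreadable from compound 1 to compound 3 cannot be sized. Compound 4 `O=C1NCCN1c1ccc(S(=O)(=O)Nc2cccc(Cl)c2)cc1` is not yet measured; it differs from compound 2 by 3-chlorophenyl in place of 2-methylphenyl on a sulfonamide nitrogen. Going by the values given here, that change sits on the sulfonamide nitrogen, the same place where compound 1 moved to compound 2, but no measured pair tells whether a 3-chlorophenyl behaves like the 2-methylphenyl or like the groups that stopped at the limit of > 1000 nM in this assay, at which 2 of the 3 values shown sit. The expectation for compound 4 is therefore a modest step, a 2.5-fold higher number from compound 2 to compound 4 (0.40 log units; beyond the scatter), toward weaker inhibition. Compound 4 is estimated at 700 nM, with a range from 200 nM to 3000 nM.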

Compound 4, half-maximal inhibitory concentration: 79 nM
Beside the measured number, compound 4's estimate is 8.9-fold (0.95 log units) above it, outside the stated range (below it).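

The change to 3-chlorophenyl gives a 3.5-fold lower number from compound 2 to compound 4 (0.55 log units; beyond the scatter), so the sulfonamide nitrogen still responds when one aromatic group replaces another with the same heavy-atom count and no net charge. Among the compounds shown here, the 2-methylphenyl is therefore not the only group at this place that gives a measured number in the assay, and a lower one is possible. Against compound 1 the change is larger, an at least 12-fold lower number from compound 1 to compound 4 (1.10 log units; beyond the scatter), but compound 1 is recorded only as a limit, so this size is a floor and not a full measure: the limit of > 1000 nM in this assay, at which 2 of the 4 values shown sit.

The change from 2-methylphenyl to 3-chlorophenyl alters both the group on the ring and its place, and the compounds shown cannot separate the two; 3-methylphenyl or 2-chlorophenyl would. On these data alone, how an amine or a carboxylic acid on this ring would read also remains open.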